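The source may hold more compounds than are shown below. What is called first, only, known or untested is meant among the compounds shown, and "the series" means these compounds.

Three compounds share one core and differ only in the group attached to the ring amine nitrogen. Compound 1 `O=c1c2cnn(-c3ccc(F)cc3)c2ncn1CC1(O)CCN(Cc2ccccn2)CC1` has "not determined" (no result reported) in an assay on Sf21 cells for inhibition of ubiquitin carboxyl-terminal hydrolase 7 (Homo sapiens), read by spectrophotometry, with stated times of 30 min and 2 h; on this read-out lower numbers stand for stronger inhibition and higher numbers for weaker inhibition. Compound 2 `O=c1c2cnn(-c3ccc(F)cc3)c2ncn1CC1(O)CCN(Cc2ccc(Cl)cc2)CC1` gives 8000 nM in this assay. Going by the values given here, compound 3 `O=c1c2cnn(-c3ccc(F)cc3)c2ncn1CC1(O)CCN(Cc2ccc(Br)cc2Cl)CC1` gives 1900 nM in this assay, the lowest of the two numbers, and the step of a 4.2-fold lower number from compound 2 to compound 3 (0.62 log units; beyond the scatter) is the only measured step. Compound 4 `COC(=O)c1ccc(CN2CCC(O)(Cn3cnc4c(cnn4-c4ccc(F)cc4)c3=O)CC2)c(Cl)c1` differs from compound 3 by methoxycarbonyl in place of bromo on an aromatic carbon. Among the compounds with values here, no measured step concerns this exchange, so the expectation for compound 4 is a step of a 1.6-fold higher number from compound 3 to compound 4 (0.20 log units; within the scatter), with no firm direction. Compound 4 is therefore estimated at 3000 nM in this assay, within a range from 1000 nM to 10000 nM.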

Compound 4, half-maximal inhibitory concentration: 800 nM
Compound 4: the middle estimate sits 3.8-fold (0.57 log units) above what was measured; measured number outside the range, below it.
By their numbers in this assay, from the lowest: compound 4; then compound 3; then compound 2.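

In this assay, the aromatic carbon para to a large group and meta to a chloro group accepts a larger group than bromo without loss: methoxycarbonyl in place of bromo gives a 2.4-fold lower number from compound 3 to compound 4 (0.38 log units; beyond the scatter). Measured against the simple 4-chlorophenyl group, 2-chloro-4-(methoxycarbonyl)phenyl gives a 10-fold lower number from compound 2 to compound 4 (1.00 log units; beyond the scatter). No measurement here explains this gain.

As far as these compounds go, whether the gain is specific to methoxycarbonyl remains open, as a carboxylic acid, an amide or a nitrile on this carbon would show. From the compounds shown here alone, it also remains open whether methoxycarbonyl would give the same gain without the chloro group.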